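A few compounds are considered here, and "the series" means these few. Any claim that something is new, unique, unknown or untested is made for them only; others in the source may bear on it.

Values measured so far in a functional assay, with a stated time of 10 min; a higher number here means a weaker inhibitor, a lower number a stronger inhibitor:

- Compound 1 `CCCCCCCCCCOc1cc(OC)c(Br)cc1C(C)=O` gives 29700000 nM
- Compound 2 `CCCCOc1cc(OC)ccc1C(C)=O` gives 57200000 nM
- Compound 3 `CCCCCCOc1cc(OC)ccc1C(C)=O` gives 84400000 nM

All three numbers are large, and a higher number here means a weaker inhibitor. Compound 3 stands level with compound 2 within the usual scatter of repeat measurements, while compound 1 shows a lower number than compound 3 by more than that scatter.

The next compound, compound 4 `CCCCCCCCCCOc1cc(OC)ccc1C(C)=O`, keeps the core of compound 3 and extends its chain, with butyl in place of hydrogen on a saturated chain carbon, six bonds along the chain from an oxygen on an aromatic ring as the change.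

Among the compounds with values here, only one measured step bears directly on this change. It is a 1.5-fold higher number from compound 2 to compound 3 (0.17 log units; within the scatter), and it also adds to the chain, with ethyl in place of hydrogen. That step is a single example and adds less than butyl does, so it is only a weak guide. Even so, it offers no sign of a real shift with chain growth. No step beyond the scatter is therefore expected in this assay, although a slight drift toward the lower number of compound 1 at 29700000 nM is possible.

The estimate amounts to an expected 1.4-fold lower number from compound 3 to compound 4 (0.15 log units; within the scatter) as the step.

For compound 4 the estimated value is 60000000 nM, with an expected range from 22000000 nM to 140000000 nM as its limits.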

Compound 4, half-maximal inhibitory concentration: 57400000 nM
Estimate against measurement, compound 4: 1.0-fold (0.02 log units) above; the range from low to high includes it.
By their numbers in this assay, from the lowest: compounds 1, 2, 4 and 3 (each within the scatter of the next, the first and the last beyond it).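

In this assay, butyl in place of hydrogen, six bonds along the chain from an oxygen on an aromatic ring, gives a 1.5-fold lower number from compound 3 to compound 4 (0.17 log units; within the scatter) and hexyl in place of hydrogen, four bonds along that chain, gives a 1.0-fold higher number from compound 2 to compound 4 (0.00 log units; within the scatter) so the chain can now be seen to grow by a much larger piece without any change beyond the scatter, and the earlier small step was no start of a trend in either direction. Within the data shown here, the result also gives the first comparison of bromo with hydrogen on an aromatic carbon, with the chain held the same: hydrogen in place of bromo gives a 1.9-fold higher number from compound 1 to compound 4 (0.29 log units; within the scatter) and this too shows no change that can be told from the scatter. Nothing measured here offers an explanation for how flat these numbers are.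

Going by these compounds, it remains open whether a longer chain, or a chain ending in an amine or a carboxylic acid, would move the number beyond the scatter at this place. It is also unknown whether chloro or a hydroxyl group on that aromatic carbon would behave as bromo and hydrogen do, or whether bromo would read the same on a shorter chain.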